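The source may report more compounds than this note shows. Statements on the series, on what has been measured and on what is new or still open speak of the compounds shown alone.

In an ADME assay (liver) for metabolic stability, with Liver microsome (Homo sapiens) as the target, read by LC-MS, using microsomes, with a stated time of 30 min, tested at 4 uM (a lower number here means that less of the compound is left, a higher number that more of the compound is left), three compounds that share a core have been measured. Compound 1 `CCN1CCN(c2nc(C)nc3c2nc(-c2ccccc2Cl)n3CCOC)CC1` gives 31%, compound 2 `Cc1nc(N2CCN(C)CC2)c2nc(-c3ccccc3Cl)n(CCN3CCCC3=O)c2n1` gives 13% and compound 3 `COc1ccccc1-c1nc2c(N3CCN(C)CC3)nc(C)nc2n1C1CCOCC1` gives 22%. The value of compound 3 lies within the usual scatter of each of the other two, so it cannot be clearly separated from either. Compound 4 `CCc1ccccc1-c1nc2c(N3CCN(C)CC3)nc(C)nc2n1C1CCOCC1` differs from compound 3 in one place, with ethyl in place of methoxy on an aromatic carbon, ortho to a large group (ethyl in place of methoxy on an aromatic carbon). Among the compounds with values here, no measured pair shows what this exchange does on its own. The expected step of a number 2 percentage points lower from compound 3 to compound 4 (within the scatter) therefore stays within the scatter, with no firm direction. For compound 4, the estimated value is 20%, with an expected range of 8% to 36%.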

Compound 4, percent of the compound remaining: 33%
The estimate for compound 4 lay 13 percentage points below the measured number; low and high end bracket the measured number.
By their numbers in this assay, from the lowest: compounds 2, 3, 1 and 4 (each within the scatter of the next, the first and the last beyond it).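

In this assay, ethyl in place of methoxy on an aromatic carbon, ortho to a large group, gives a number 11 percentage points higher from compound 3 to compound 4 (beyond the scatter). Within the data shown here, this is the first reading of this exchange on its own, and it shows that the oxygen of the methoxy group is not needed at this position for more of the compound to be left. Nothing available explains the step. On these data alone, whether a longer chain such as propyl, or a nitrile, would give a higher or lower number at this place remains open. So does whether the exchange gives a similar step when the other parts of the molecule differ.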